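This account rests on a few compounds, and the source may have more. Where it says the series, first, only, none or still open, it means among the compounds named here.

Measured in a functional assay on HT-29 cells (Homo sapiens) for inhibition, with a stated time of 72 h; on this read-out higher numbers stand for weaker inhibition and lower numbers for stronger inhibition:

- compound 1 `COc1ccc(S(=O)(=O)N2CCc3cccc(-c4ccc(N(C)C)cc4)c32)cc1`: 467 nM
- compound 2 `COc1ccc(S(=O)(=O)n2ccc3cccc(-c4ccc(C#N)cc4)c32)cc1`: 164 nM
- compound 3 `COc1ccc(S(=O)(=O)N2CCc3cccc(-c4c(F)c(F)c(F)c(F)c4F)c32)cc1`: 3900 nM

Compound 1 holds the middle place among these three numbers. Compound 2 at 164 nM lies lower and compound 3 at 3900 nM lies higher, and both gaps from compound 1 go beyond the usual scatter.

The next compound to be tested is compound 4 `COc1ccc(S(=O)(=O)N2CCc3cccc(-c4ccc(O)cc4)c32)cc1`. It keeps the core of compound 1 and changes one group: hydroxy stands in place of dimethylamino on an aromatic carbon, para to a large group, in the six-membered aromatic ring of carbon only (hydroxy in place of dimethylamino on an aromatic carbon).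

Going by the values given here, no measured pair isolates this change, so the data offer no direct precedent for its size or direction. With nothing to point either way, the expectation stays anchored on compound 1 at 467 nM. In this assay the expected change is small, a slight move toward stronger inhibition that stays within the scatter: a 1.2-fold lower number from compound 1 to compound 4 (0.07 log units; within the scatter). The three measured numbers are spread widely, so the expected range is kept broad. For compound 4 the estimated value is 400 nM, with an expected range of 120 nM to 1400 nM.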

Compound 4, half-maximal inhibitory concentration: 133 nM
Compound 4: middle estimate off by 3.0-fold (0.48 log units), on the high side; the range from low to high includes it.
By their numbers in this assay, from the lowest: compounds 4 and 2 (each within the scatter of the next); then compound 1; then compound 3.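

In this assay, going by these compounds alone, this is the first pair that differs in one place, and it shows that the group on this aromatic carbon, para to a large group, affects the read-out: hydroxy in place of dimethylamino gives a 3.5-fold lower number from compound 1 to compound 4 (0.55 log units; beyond the scatter), a modest step beyond the scatter. The exchange replaces a larger group that has no hydrogen-bond donor with a smaller one that has a hydrogen-bond donor, and this single pair cannot separate those two differences. No measurement shown here accounts for the step.

The compounds shown leave open whether the hydroxy hydrogen matters at this place, which methoxy could test, and whether a primary amine or a carboxylic acid on the same carbon would give a number closer to that of compound 4 or of compound 1. They also leave open whether the exchange of dimethylamino for hydroxy would produce a step of similar size and direction on the core of compound 2.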